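A few compounds are considered here, and "the series" means these few. Any claim that something is new, unique, unknown or untested is made for them only; others in the source may bear on it.

Of the compounds shown here, two with a shared core have been measured in an ADME assay on HEK293 cells (Homo sapiens) for cytotoxicity, read by CCK-8 assay and cell counting, with a stated time of 2 days; on this read-out lower numbers stand for stronger inhibition and higher numbers for weaker inhibition. Compound 2 `Oc1ccc(-c2cc(-c3cccc(Cl)c3)nc(-c3ccco3)c2)cc1` carries a furan-2-yl group and a 3-chlorophenyl group beside the 4-hydroxyphenyl group on the core, and in this assay compound 2 gives 2880 nM. Compound 1 `Oc1ccc(-c2cc(-c3ccccc3)nc(-c3ccccc3Cl)c2)cc1` instead carries a phenyl group and a 2-chlorophenyl group, and in this assay compound 1 gives 3930 nM. These two numbers lie within the usual scatter of each other, so they show no real gap between compound 1 and compound 2.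

Compound 3 `Oc1ccc(-c2cc(-c3ccccc3)nc(-c3cccc(Cl)c3)c2)cc1` has not yet been measured in this assay. It differs from compound 2 in one place: phenyl in place of furan-2-yl on an aromatic carbon. Among the compounds with values here, no step between two measured compounds covers this exchange, so there is nothing measured to set its size. Both measured compounds sit close together, and compound 1 already shows that a phenyl group on the core is compatible with a number of 3930 nM. The expected step from compound 2 to compound 3 is therefore small, a 1.2-fold higher number from compound 2 to compound 3 (0.08 log units; within the scatter), with no direction beyond the scatter. Compound 3 is estimated to give 3500 nM in this assay, within a range from 1500 nM to 8000 nM.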

Compound 3, half-maximal inhibitory concentration: 2820 nM
Compound 3: middle estimate off by 1.2-fold (0.09 log units), on the high side; the measured number falls inside the stated range.
By their numbers in this assay, from the lowest: compounds 3, 2 and 1 (each within the scatter of the next).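

In this assay, the exchange of furan-2-yl for phenyl on the aromatic carbon next to the ring nitrogen gives a step (a 1.0-fold lower number from compound 2 to compound 3 (0.01 log units; within the scatter)) that lies within the scatter, so a five-membered aromatic ring with one oxygen and a six-membered aromatic ring of carbon only cannot be told apart here by this read-out. The exchange of 2-chlorophenyl for 3-chlorophenyl gives a step (a 1.4-fold lower number from compound 1 to compound 3 (0.14 log units; within the scatter)) that also lies within the scatter, so these two chlorophenyl groups cannot be told apart in this assay either. Nothing measured beyond these numbers bears on why neither exchange produces a real difference.

On these data alone, both exchanges keep an aromatic ring in place, so it stays open how this assay would read for an amine, a carboxylic acid or a longer chain on the carbon next to the ring nitrogen. As far as these compounds go, the 4-hydroxyphenyl group is the same in all three compounds, so it is also open what a methoxy group in place of its hydroxyl would do to the number.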